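A few compounds are considered here, and "the series" means these few. Any claim that something is new, unique, unknown or untested is made for them only; others in the source may bear on it.

Series notes. In an assay on cells for agonist activity at ecdysone receptor (Bombyx mori), read by a luciferase reporter, with a stated time of 24 h (on this read-out lower numbers stand for an effect already at smaller amounts and higher numbers for an effect only at larger amounts of compound), compound 1 `CC(C)(C)N(NC(=O)c1ccccc1I)C(=O)c1ccccc1Cl` gives 1290 nM; compound 2 `Cc1ccccc1C(=O)NN(C(=O)c1ccccc1Cl)C(C)(C)C` gives 72.4 nM; compound 3 `CC(C)(C)N(NC(=O)c1cccc(F)c1)C(=O)c1ccccc1Cl` gives 69.2 nM. Compound 2 and compound 3 sit together at the low end of this assay, separated only by a 1.0-fold lower number from compound 2 to compound 3 (0.02 log units; within the scatter), while compound 1 stands apart by a 19-fold lower number from compound 1 to compound 3 (1.27 log units; beyond the scatter) and an 18-fold lower number from compound 1 to compound 2 (1.25 log units; beyond the scatter). Compound 4 `CC(C)(C)N(NC(=O)c1ccc(F)cc1)C(=O)c1ccccc1Cl` carries 4-fluorophenyl in place of 3-fluorophenyl on a carbonyl carbon. Among the measured compounds shown here, the only measured aryl swap on that carbonyl carbon is a 1.0-fold lower number from compound 2 to compound 3 (0.02 log units; within the scatter), which moved nothing beyond the scatter; no measured step tests the position of a single fluoro. The expected step of a 1.1-fold higher number from compound 3 to compound 4 (0.03 log units; within the scatter) in this assay is therefore none beyond the scatter. Compound 4 is estimated at 75 nM, within a range of 25 nM to 250 nM.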

Compound 4, half-maximal effective concentration: 389 nM
Compound 4: middle estimate off by 5.2-fold (0.71 log units), on the low side; measured number above the stated range.
By their numbers in this assay, from the lowest: compounds 3 and 2 (each within the scatter of the next); then compound 4; then compound 1.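

Moving the single fluoro on this carbonyl carbon's aryl group, with the atoms unchanged, is not neutral in this assay (a 5.6-fold higher number from compound 3 to compound 4 (0.75 log units; beyond the scatter)), although the earlier swap of aryl groups here stayed within the scatter. The 4-fluorophenyl group falls between the other aryl groups, both steps being beyond the scatter (a 5.4-fold higher number from compound 2 to compound 4 (0.73 log units; beyond the scatter); a 3.3-fold lower number from compound 1 to compound 4 (0.52 log units; beyond the scatter)). No evidence accounts for the effect of the fluoro position.

On these data alone, it remains open whether 4-chlorophenyl or 4-methoxyphenyl on this carbonyl carbon would track compound 3 or compound 4.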